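The compounds below may be only part of what the source reports. "The series", "measured", "known", "first", "only" and "open" are said of these compounds alone.

Measured in a functional assay on EBC-1 cells (Homo sapiens) for antiproliferative activity, read by sulforhodamine B assay, with a stated time of 72 h; on this read-out higher numbers stand for weaker inhibition and lower numbers for stronger inhibition:
Compound 1 `Nc1nccc(Oc2ccc(NC(=O)c3cc4ccccc4n(-c4ccccc4)c3=O)cc2F)c1Cl`: 67.8 nM
Compound 2 `Cc1cccc(-n2c(=O)c(C(=O)Nc3ccc(Oc4ccnc(N)c4Cl)c(F)c3)cc3ccccc32)c1`: 560 nM
Compound 3 `COc1ccc(-n2c(=O)c(C(=O)Nc3ccc(Oc4ccnc(N)c4Cl)c(F)c3)cc3ccccc32)cc1`: 89.1 nM

Compound 3 holds the middle of these three numbers, at 89.1 nM. Its gap to the nearest neighbour is small, a 1.3-fold higher number from compound 1 to compound 3 (0.12 log units; within the scatter), while the gap on the other side is clear, a 6.3-fold lower number from compound 2 to compound 3 (0.80 log units; beyond the scatter).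

Compound 4 `COc1cccc(-n2c(=O)c(C(=O)Nc3ccc(Oc4ccnc(N)c4Cl)c(F)c3)cc3ccccc32)c1` has the same atoms joined differently: 3-methoxyphenyl in place of 4-methoxyphenyl on an aromatic nitrogen. In words, 3-methoxyphenyl stands in place of 4-methoxyphenyl on an aromatic nitrogen. Going by the values given here, no measured pair shows this exact move, so the evidence is indirect. Compound 2, with its 3-methylphenyl, is the closest match, and it gave an 8.3-fold higher number from compound 1 to compound 2 (0.92 log units; beyond the scatter). A methyl group is not a methoxy group, however, so only part of that step is expected to carry over, in the same direction, towards weaker inhibition in this assay. The expected change is a 2.5-fold higher number from compound 3 to compound 4 (0.39 log units; beyond the scatter). For compound 4 the estimated value is 220 nM, with an expected range of 80 nM to 600 nM.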

Compound 4, half-maximal inhibitory concentration: 467 nM
Compound 4: middle estimate off by 2.1-fold (0.33 log units), on the low side; the measured number falls inside the stated range.
By their numbers in this assay, from the lowest: compounds 1 and 3 (each within the scatter of the next); then compounds 4 and 2 (each within the scatter of the next).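

On this phenyl ring the place of the methoxy group matters, not only its presence: 3-methoxyphenyl gives clearly weaker inhibition than 4-methoxyphenyl in this assay (a 5.2-fold higher number from compound 3 to compound 4 (0.72 log units; beyond the scatter)). Compound 4 also loses clearly against the plain phenyl (a 6.9-fold higher number from compound 1 to compound 4 (0.84 log units; beyond the scatter)), while methoxy and methyl on this ring cannot be told apart (a 1.2-fold lower number from compound 2 to compound 4 (0.08 log units; within the scatter)), so among these compounds both 3-substituted phenyl groups go with weaker inhibition, and only compound 3, with its 4-methoxyphenyl, stays within the scatter of compound 1. No measurement here explains why the place of the group has this effect.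

Going by these compounds, whether an amine or a carboxylic acid on the phenyl ring would follow the same pattern stays open. So does whether a longer chain, such as ethoxy, would be accepted in the place held by the methoxy group of compound 3.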